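A few compounds are considered here, and "the series" means these few. Any claim that something is new, unique, unknown or untested is made for them only; others in the source may bear on it.

Measured compounds:
compound 1, `CCCCOC(=O)Nc1ccc(S(=O)(=O)N2C[C@H](c3ccccc3)NC2=O)cc1CC`: 200 nM
compound 2, `CCOC(=O)Nc1c(C)cc(S(=O)(=O)N2C[C@H](c3ccccc3)NC2=O)cc1C`: > 10000 nM

Within the data shown here, of the two values recorded in a functional assay on NCI-H460 cells (Homo sapiens) for cytotoxicity, read by MTT assay (a lower number here means a stronger inhibitor, a higher number a weaker inhibitor), compound 1 supplies the only actual number, 200 nM. Compound 2 is recorded only as the limit of > 10000 nM in this assay, at which 1 of the 2 values shown sits, a limit of the assay rather than a measured number. Compound 3, `CCCOC(=O)Nc1ccc(S(=O)(=O)N2C[C@H](c3ccccc3)NC2=O)cc1CC`, has yet to be tested in this assay. It differs from compound 1 by hydrogen in place of methyl on a saturated chain carbon, three bonds along the chain from an oxygen next to a carbonyl group, which read one bond further out is butyl to propyl on the carbamate chain. Among the measured compounds shown here, no step between measured compounds matches this change, so the expectation rests on the change itself: a shortening of the carbamate chain by a single methyl is expected to shift the half-maximal inhibitory concentration little, likely not beyond the usual scatter, with no clear direction. Compound 3 is therefore estimated at 250 nM, within 100 nM to 700 nM. The step this implies, a 1.3-fold higher number from compound 1 to compound 3 (0.10 log units; within the scatter), is expected to be small.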

Compound 3, half-maximal inhibitory concentration: 60 nM
The estimate for compound 3 lay 4.2-fold (0.62 log units) above the measured number; measured number below the stated range.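

In this assay the carbamate chain proves to matter at this place: butyl to propyl, hydrogen in place of methyl on a saturated chain carbon, gives a 3.3-fold lower number from compound 1 to compound 3 (0.52 log units; beyond the scatter), a modest step. Among these compounds, this is the first pair that differs in one place, so it is the first reading of this chain on its own, and here propyl carries the lower number. Compound 2 differs from the other two in more than one place, so it offers no comparison, and it stands only as a limit of the assay: the limit of > 10000 nM in this assay, at which 1 of the 3 values shown sits.

On these data alone, a single step sets no trend, and whether a longer chain such as pentyl, or an amine at the end of the chain, would follow this direction stays open. The compounds shown give no reason for the step.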